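The source may report more compounds than this note shows. Statements on the series, on what has been measured and on what is new or still open speak of the compounds shown alone.

Compound 1 `COc1cccc(OC)c1-c1nnc(-c2cc([N+](=O)[O-])cn2C)o1` is one of three compounds that have been tested in an ADME assay on Vero cells (Chlorocebus sabaeus) for cytotoxicity, read by MTT assay, with a stated time of 72 h; on this read-out lower numbers stand for stronger inhibition and higher numbers for weaker inhibition; in that assay compound 1 gives 177000 nM. Two further compounds share a different core with one another: compound 2 `Cn1cc([N+](=O)[O-])cc1-c1nnc(-c2cc(-c3ccccc3)nc3ccc(Cl)cc23)o1` gives 328000 nM and compound 3 `O=[N+]([O-])c1c[nH]c(-c2nnc(-c3cc(-c4ccccc4)nc4ccc(Cl)cc34)o2)c1` gives 281000 nM. The difference between the core of compound 1 and the core of compound 2 is not broken down here. Compounds 2 and 3 differ in one place, (hydrogen in place of methyl on an aromatic nitrogen), and the step this made is a 1.2-fold lower number from compound 2 to compound 3 (0.07 log units; within the scatter). The three numbers all lie close together, and none of the gaps among them is larger than what repeated measurements of this kind would themselves show.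

Compound 4 `COc1cccc(OC)c1-c1nnc(-c2cc([N+](=O)[O-])c[nH]2)o1` has not yet been measured. It differs from compound 1 in one place, (hydrogen in place of methyl on an aromatic nitrogen), which is the same change as that from compound 2 to compound 3, made on the other core. Among the compounds with values here, since compound 2 and compound 3 showed a step within the scatter, the expectation for compound 1 to compound 4 is a step of similar size, namely a 1.2-fold lower number from compound 1 to compound 4 (0.07 log units; within the scatter), and this expectation rests on the one measured pair, compound 2 to compound 3 with its step of a 1.2-fold lower number from compound 2 to compound 3 (0.07 log units; within the scatter). In this assay compound 4 is therefore expected to give about 150000 nM, with a range from 70000 nM to 320000 nM.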

Compound 4, half-maximal inhibitory concentration: 170000 nM
Compound 4: middle estimate off by 1.1-fold (0.05 log units), on the low side; measured number inside the range.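

In this assay, putting hydrogen in place of methyl on the aromatic nitrogen gives a 1.0-fold lower number from compound 1 to compound 4 (0.02 log units; within the scatter), and this step agrees with the one seen on the other core: the same change on two cores in this assay, a 1.2-fold lower number (0.07 log units; within the scatter) from compound 2 to compound 3 and a 1.0-fold lower number (0.02 log units; within the scatter) from compound 1 to compound 4, 1.1-fold (0.05 log units) apart, within the scatter of two such steps. On the two cores shown, then, the change carries over in the limited sense that neither step can be told apart from repeated measurement, and the core of compound 1 behaves no differently here from the core shared by compound 2 and compound 3. Within the data shown here, this does not show that a real effect of the change is transferred from one core to the other, since a step within the scatter offers no clear effect to carry, and the comparison rests on only two pairs of compounds in a single assay.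

All four compounds shown bear either methyl or hydrogen on that aromatic nitrogen, so it remains open whether an ethyl group, a longer chain or an acetyl group there would also leave the number unchanged within the scatter on both cores. On these data alone, all four also keep the nitro group, so it remains equally open how the series would respond if a nitrile, an amine or a carboxylic acid stood in its place.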